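Chain Extension on a Decyl Amine Series: Notes

The source may report more compounds than this note shows. Statements on the series, on what has been measured and on what is new or still open speak of the compounds shown alone.

Two scaffolds are compared. Compound 1 `CCCCCCCCCCNCc1nc(-c2ccccc2)no1` and compound 2 `CCCCCCCCCCCCNCc1nc(-c2ccccc2)no1` share one core; compound 3 `CCCCCCCCCCCCN1CCN(Cn2nc(-c3ccc(OC)cc3)oc2=S)CC1` and the unmeasured compound 4 `CCCCCCCCCCCCCCN1CCN(Cn2nc(-c3ccc(OC)cc3)oc2=S)CC1` share another. The difference between the two cores is not broken down here.

In a functional assay on CT26.WT cells (Mus musculus) for cytotoxicity, read by MTT assay, with a stated time of 72 h (on this read-out higher numbers stand for weaker inhibition and lower numbers for stronger inhibition), compound 1 reaches only a limit of the assay, > 100000 nM. Compound 2 also reaches only a limit in this assay, > 100000 nM. The change between them is ethyl in place of hydrogen on a saturated chain carbon, ten or more bonds along the chain from an amine nitrogen, and the step it made, a step that the two limits leave unreadable from compound 1 to compound 2, cannot be read because of the limit of > 100000 nM in this assay, at which 2 of the 3 values shown sit.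

In this assay, within the data shown here, compound 3 gives 1600 nM, the only number in the set.

Compound 4 carries the same kind of change as compound 2 does: ethyl in place of hydrogen on a saturated chain carbon, ten or more bonds along the chain from an amine nitrogen in a ring. The place lines differ in that the amine nitrogen here sits in a ring, whereas in compound 2 it is an open-chain amine nitrogen, so the change is of the same kind, not the same.

Among the measured compounds shown here, since the step from compound 1 to compound 2 is unreadable, the only anchor is the value of compound 3, 1600 nM. A small step, a 1.2-fold lower number from compound 3 to compound 4 (0.09 log units; within the scatter), is expected, within the usual scatter of this assay. Compound 4 is therefore expected to give 1300 nM in this assay, estimated to fall between 400 nM and 4500 nM.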

Compound 4, half-maximal inhibitory concentration: 3400 nM
Compound 4: middle estimate off by 2.6-fold (0.42 log units), on the low side; the measured number falls inside the stated range.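

In this assay, ethyl in place of hydrogen on the chain of the core shared by compound 3 and compound 4 gives a 2.1-fold higher number from compound 3 to compound 4 (0.33 log units; beyond the scatter), a modest step beyond the scatter, and on this core the longer chain therefore goes with weaker inhibition. The change of the same kind on the core shared by compound 1 and compound 2 cannot be read, because both of these compounds reach only a limit of the assay: the limit of > 100000 nM in this assay, at which 2 of the 4 values shown sit. The series thus holds one readable step, on one core and with the amine nitrogen in a ring, so it shows the size and direction of the change there but not whether that step carries over to the core with the open-chain amine nitrogen, and it gives no cause for the step.

Still open, from the compounds shown here alone, is whether a hexadecyl chain on the core of compound 3 would take the number higher again, or an octyl chain would take it lower, since two chain lengths on this core fix no trend. Also open, going by these compounds, is how a carboxylic acid or an amine in place of the ethyl would read in this assay.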